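The source may report more compounds than this note shows. Statements on the series, on what has been measured and on what is new or still open speak of the compounds shown alone.

Measured so far in a functional assay on HL-60 cells (Homo sapiens) for inhibition, read by MTT assay, with a stated time of 48 h; on this read-out lower numbers stand for stronger inhibition of growth and higher numbers for weaker inhibition of growth:
- compound 1 `CN1CC[C@H](c2c(O)cc(O)c3c(=O)cc(/C=C/c4ccccc4)oc23)[C@H](O)C1`: 1000 nM
- compound 2 `CN1CC[C@H](c2c(O)cc(O)c3c(=O)cc(/C=C/c4ccc(Cl)cc4)oc23)[C@H](O)C1`: 8000 nM

Compound 2 holds the higher of the two numbers in this assay, so it is the weaker growth inhibitor of the pair. Compound 3 `CN1CC[C@H](c2c(O)cc(O)c3c(=O)cc(/C=C/c4cccc(Cl)c4)oc23)[C@H](O)C1` has the same atoms as compound 2, joined differently: 3-chlorophenyl stands in place of 4-chlorophenyl on a double-bonded chain carbon bound to a double-bonded chain carbon (3-chlorophenyl in place of 4-chlorophenyl on a double-bonded chain carbon bound to a double-bonded chain carbon).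

For the measured compounds named here, only one measured step bears on this change: an 8.0-fold higher number from compound 1 to compound 2 (0.90 log units; beyond the scatter), a modest step for chloro in place of hydrogen on an aromatic carbon. Going by the values given here, that step shows what adding the chloro did, and no measurement yet shows what moving it does. Compound 3 still carries a chloro, so a number between compound 1 at 1000 nM and compound 2 at 8000 nM is expected, though with little certainty. A step smaller than the measured one is therefore expected, towards a lower number. The expected step is a 2.3-fold lower number from compound 2 to compound 3 (0.36 log units; beyond the scatter). For compound 3 the estimated value is 3500 nM, with an expected range of 1100 nM to 11000 nM.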

Compound 3, concentration for 50% growth inhibition: 20000 nM
Estimate against measurement, compound 3: 5.7-fold (0.76 log units) below, outside the stated range (above it).
By their numbers in this assay, from the lowest: compound 1; then compound 2; then compound 3.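

In this assay the place of the chloro counts as well as its presence: the change to 3-chlorophenyl from 4-chlorophenyl gives a 2.5-fold higher number from compound 2 to compound 3 (0.40 log units; beyond the scatter) even though the two groups have the same atoms. Set against the hydrogen of compound 1, the chloro in 3-chlorophenyl brings a 20-fold higher number from compound 1 to compound 3 (1.30 log units; beyond the scatter) and is thus a large step, whereas the chloro in 4-chlorophenyl brought the modest 8.0-fold higher number from compound 1 to compound 2 (0.90 log units; beyond the scatter) in the same direction, so both chlorinated compounds are weaker growth inhibitors than compound 1. Nothing available accounts for this difference between the two placements.

The compounds shown leave open whether this order belongs to the chloro or would also appear with another group, such as a bromo, a methoxy or an amine, in these same two placements on the phenyl. They also leave open whether any group on this phenyl can give a stronger inhibitor than the plain phenyl of compound 1, since both substituents so far carry chloro and both moved the number upwards.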